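Methyl in place of trifluoromethyl: toward compound 4

A few compounds are considered here, and "the series" means these few. Any claim that something is new, unique, unknown or untested is made for them only; others in the source may bear on it.

Compound 1 `COc1cc2ncnc(NNC(=S)NC(=O)c3ccc(C(F)(F)F)cc3)c2cc1OC` gives 16800 nM in a functional assay on MCF7 cells (Homo sapiens) for cytotoxicity, read by MTT assay, with a stated time of 72 h (a higher number here means a weaker inhibitor, a lower number a stronger inhibitor), the highest number shown, though compound 2 sits within the scatter of it. Compound 2 `COc1cc2ncnc(NNC(=S)NC(=O)c3cccc(Cl)c3)c2cc1OC` gives 11500 nM, which is a 1.5-fold lower number from compound 1 to compound 2 (0.16 log units; within the scatter). Among the measured compounds shown here, compound 3 `O=C(NC(=S)NNc1ncnc2ccccc12)c1ccc(Cl)cc1`, on a different core, gives 5960 nM; its gap to compound 1 is the only one here beyond the scatter, and no single step connects the two. Compound 4 `COc1cc2ncnc(NNC(=S)NC(=O)c3ccc(C)cc3)c2cc1OC` differs from compound 1 by methyl in place of trifluoromethyl on an aromatic carbon. For the measured compounds named here, the one measured step bearing on it, the change of the group on the carbonyl carbon from compound 1 to compound 2, stayed within the scatter; nothing in hand separates methyl from trifluoromethyl. No step beyond the scatter is therefore expected in this assay for compound 4, with a 1.2-fold lower number from compound 1 to compound 4 (0.08 log units; within the scatter). Compound 4 is estimated at 14000 nM, between 6000 nM and 35000 nM.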

Compound 4, half-maximal inhibitory concentration: 22300 nM
The estimate for compound 4 lay 1.6-fold (0.20 log units) below the measured number; the measured number falls inside the stated range.
By their numbers in this assay, from the lowest: compounds 3, 2, 1 and 4 (each within the scatter of the next, the first and the last beyond it).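

In this assay, methyl in place of trifluoromethyl on an aromatic carbon para to a large group gives a 1.3-fold higher number from compound 1 to compound 4 (0.12 log units; within the scatter) and does not separate the two groups at this position. The 4-methylphenyl group in place of 3-chlorophenyl gives a 1.9-fold higher number from compound 2 to compound 4 (0.29 log units; within the scatter) so compound 1, compound 2 and compound 4 all lie within the scatter of one another on the shared core. No measurement on hand bears on the reason for this result.

Going by these compounds, whether an amine or a carboxylic acid on this aromatic carbon would give a step beyond the scatter stays open. Among the compounds shown here, also open is what the core alone contributes, as no single step links compound 3 to the others.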